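The source may hold more compounds than are shown below. What is called first, only, known or untested is meant among the compounds shown, and "the series" means these compounds.

Compound 3 `CC(c1ccc(-c2ccccc2)c(F)c1)c1nnc2n1N=C(c1ccc(Br)cc1)CS2` gives 7400 nM in a functional assay on MCF7 cells (Homo sapiens) for inhibition, read by sulforhodamine B assay, with a stated time of 72 h (a lower number here means a stronger inhibitor, a higher number a weaker inhibitor), which places it second highest of the three numbers recorded there: compound 1 `CC(c1ccc(-c2ccccc2)c(F)c1)c1nnc2n1N=C(c1ccc(C(F)(F)F)cc1)CS2` gives 4300 nM and compound 2 `CC(c1ccc(-c2ccccc2)c(F)c1)c1nnc2n1N=C(c1ccc(Cl)cc1)CS2` gives 8700 nM. Compound 4 `CC(c1ccc(-c2ccccc2)c(F)c1)c1nnc2n1N=C(c1ccc(F)cc1)CS2` differs from compound 3 by fluoro in place of bromo on an aromatic carbon, on an aromatic carbon of a six-membered aromatic ring of carbon only. For the measured compounds named here, three measured steps bear on this change at the same carbon: a 1.7-fold higher number from compound 1 to compound 3 (0.24 log units; within the scatter), a 1.2-fold lower number from compound 2 to compound 3 (0.07 log units; within the scatter) and a 2.0-fold higher number from compound 1 to compound 2 (0.31 log units; beyond the scatter). Swapping the group on that carbon has so far moved this assay by little, so for compound 4 no step beyond the scatter is expected, leaning if anything toward a slightly higher number. Compound 4 is therefore estimated at 8500 nM, with a range from 4000 nM to 18000 nM. The expected step reads a 1.1-fold higher number from compound 3 to compound 4 (0.06 log units; within the scatter).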

Compound 4, half-maximal inhibitory concentration: 8100 nM
Estimate against measurement, compound 4: 1.0-fold (0.02 log units) above, and the stated range covers the measured number.
By their numbers in this assay, from the lowest: compounds 1, 3, 4 and 2 (each within the scatter of the next, the first and the last beyond it).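

Within this assay fluoro in place of bromo gives a 1.1-fold higher number from compound 3 to compound 4 (0.04 log units; within the scatter) and fluoro in place of chloro gives a 1.1-fold lower number from compound 2 to compound 4 (0.03 log units; within the scatter) so the three halogens on this carbon cannot be told apart. Fluoro in place of trifluoromethyl gives a 1.9-fold higher number from compound 1 to compound 4 (0.28 log units; within the scatter) and so stays inside the scatter, which leaves chloro as the only halogen whose step from compound 1 goes beyond it.

On these data alone, whether an amine, a carboxylic acid or a methoxy group on this carbon would move the number further remains open. No measurement shown here accounts for how small these steps are.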